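The source may report more compounds than this note shows. Statements on the series, on what has been measured and on what is new or still open speak of the compounds shown alone.

Measured so far:
- compound 1 `Cc1cc(OCc2nc3ccccc3s2)ccc1NC(=O)Nc1cccc(Cl)c1` — 160 nM
- compound 2 `Cc1cc(NC(=O)Nc2ccccc2)ccc1OCc1nc2ccccc2s1` — 2070 nM

In an assay on isolated protein for inhibition of Polyunsaturated fatty acid 5-lipoxygenase (Homo sapiens), read by HPLC, with a stated time of 10 min (a lower number here means a stronger inhibitor, a higher number a weaker inhibitor), compound 1 gives 160 nM, while compound 2 gives 2070 nM. Compound 2 thus carries the higher of the two numbers; the gap to compound 1 lies well beyond the usual scatter, so compound 2 is the weaker inhibitor of the pair. The two structures differ in more than one place, so no single change can be read from that gap.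

Compound 3 `Cc1cc(NC(=O)Nc2ccc(Cl)cc2)ccc1OCc1nc2ccccc2s1` differs from compound 2 in one place only: chloro in place of hydrogen on an aromatic carbon. Among the compounds with values here, no measured pair shows what this particular change does here, so the expectation rests on general experience that a single chloro on an outer ring shifts such numbers only modestly, usually towards a stronger inhibitor. The step from compound 2 to compound 3 is therefore expected to be a 2.3-fold lower number from compound 2 to compound 3 (0.36 log units; beyond the scatter), downward but near the edge of the scatter. Compound 3 is estimated at 900 nM, with a likely range from 300 nM to 2700 nM.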

Compound 3, half-maximal inhibitory concentration: > 10000 nM
Compound 3: only a limit was reported; the forecaster's own chance of this, stated with the estimate: 5%; middle value at least 11-fold (1.04 log units) from the limit.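

Going from phenyl to 4-chlorophenyl adds just one heavy atom, yet in this assay it gives an at least 4.8-fold higher number from compound 2 to compound 3 (0.68 log units; beyond the scatter), so compound 3 is a weaker inhibitor and this position is not indifferent to change. The pair of compound 1 and compound 2 could not show this, as those two structures differ in more than one place. The value of compound 3 is a limit of the assay and not a number, so the step gives only a minimum size and the true gap stays unknown: the limit of > 10000 nM in this assay, at which 1 of the 3 values shown sits.

The compounds shown leave open whether this drop is particular to chloro or would also follow from another group at this place, such as fluoro, methyl or an amine. They also leave open what the same chloro would do at another carbon of this ring in the core of compound 2.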